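Swapping Phenoxy for Benzyl in a Receptor Antagonist Series

The source may report more compounds than this note shows. Statements on the series, on what has been measured and on what is new or still open speak of the compounds shown alone.

Compound 1, with the structure `COc1cc(OCc2cccc(COc3ccccc3)c2)c2cc(-c3cn4nc(OC)sc4n3)oc2c1`, is the most potent of the three compounds measured here. In an assay on a cell-free system (plasma) for antagonist activity at proteinase-activated receptor 4 (Homo sapiens), with a stated time of 5 min, in the presence of a further agent that is not named here (a higher number here means a weaker inhibitor, a lower number a stronger inhibitor), compound 1 gives 600 nM. Compound 3, `COc1nn2cc(-c3cc4c(OC)ccc(OC)c4o3)nc2s1`, gives 10000 nM in this assay, a gap from compound 1 that lies well beyond the usual scatter. Compound 2, `COc1nn2cc(-c3cc4ccc(OCc5ccccc5)cc4o3)nc2s1`, reaches only a limit of the assay, > 30000 nM, so no number is known for it; this limit is noted as the limit of > 30000 nM in this assay, at which 1 of the 3 values shown sits.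

Compound 4, `COc1cc(OCc2cccc(CCc3ccccc3)c2)c2cc(-c3cn4nc(OC)sc4n3)oc2c1`, has not yet been measured. It differs from compound 1 in a single place: benzyl in place of phenoxy on a saturated chain carbon bound to an aromatic carbon, so the ether oxygen that links the outer ring in compound 1 becomes a saturated carbon in compound 4, while the rest of the molecule is unchanged. Among the measured compounds shown here, no measured pair among the three compounds shows a change of this kind, so there is no direct precedent. The shift is expected to be modest, within or close to the scatter, and the step from compound 1 to compound 4 is estimated at a 1.3-fold higher number from compound 1 to compound 4 (0.12 log units; within the scatter). Compound 4 is therefore expected to give about 800 nM in this assay, most likely between 200 nM and 4000 nM.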

Compound 4, half-maximal inhibitory concentration: 1200 nM
Beside the measured number, compound 4's estimate is 1.5-fold (0.18 log units) below it; measured number inside the range.
By their numbers in this assay, from the lowest: compounds 1 and 4 (each within the scatter of the next); then compound 3. At a limit, above all of these: compound 2.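

Among the compounds shown here, this is the first comparison here of two compounds that differ in one place: in this assay, benzyl in place of phenoxy gives a 2.0-fold higher number from compound 1 to compound 4 (0.30 log units; within the scatter). Phenoxy counts one hydrogen-bond acceptor and benzyl none, yet on this saturated chain carbon bound to an aromatic carbon, the exchange of the linking oxygen for a carbon leaves the two compounds within the usual scatter of each other. Nothing measured here accounts for how close the two values lie.

This single pair leaves open how the same place would respond to a different group, such as an amine, a carboxylic acid or a longer chain. It also leaves open whether the same exchange would give a similar step on another core.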